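The source may hold more compounds than are shown below. What is called first, only, known or untested is meant among the compounds shown, and "the series" means these compounds.

In a functional assay on SW480 cells (Homo sapiens) for inhibition (on this read-out lower numbers stand for stronger inhibition and higher numbers for weaker inhibition), compound 1 `COc1cc[nH]c1/C=C1\C(=O)Nc2ccc(F)c(C#C[C@@H](C)O)c21` gives 130 nM. Compound 2 `CN[C@@H](C#Cc1c(F)ccc2c1/C(=C/c1[nH]ccc1OC)C(=O)N2)CO` gives 80 nM, and compound 3 `CN[C@H](C#Cc1c(F)ccc2c1/C(=C/c1[nH]ccc1OC)C(=O)N2)CO` gives 100 nM. Compound 3 sits within the scatter of both of the others: a 1.3-fold lower number from compound 1 to compound 3 (0.11 log units; within the scatter) and a 1.3-fold higher number from compound 2 to compound 3 (0.10 log units; within the scatter), the second comparison resting on (the fact that compounds 2 and 3 differ only in the configuration as drawn). Compound 4 `COc1cc[nH]c1/C=C1\C(=O)Nc2ccc(F)c(C#C[C@H](CO)NCCO)c21` differs from compound 3 by hydroxymethyl in place of hydrogen on a saturated chain carbon bound to an amine nitrogen. The measured steps that bear on this change are those that brought in the amine-bearing chain, a 1.6-fold lower number from compound 1 to compound 2 (0.21 log units; within the scatter) and a 1.3-fold lower number from compound 1 to compound 3 (0.11 log units; within the scatter), and both were small. Lengthening the substituent on that amine is therefore expected to do little, so in this assay compound 4 is expected to show no change at the digits printed from compound 3 to compound 4 (within the scatter). Compound 4 is estimated at 100 nM, with a range from 50 nM to 220 nM.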

Compound 4, half-maximal inhibitory concentration: 967 nM
Estimate against measurement, compound 4: 9.7-fold (0.99 log units) below, and the stated range ends below it.
By their numbers in this assay, from the lowest: compounds 2, 3 and 1 (each within the scatter of the next); then compound 4.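

In this assay the substituent on the amine proves not to be silent: hydroxymethyl on the saturated chain carbon bound to the amine nitrogen gives a 9.7-fold higher number from compound 3 to compound 4 (0.99 log units; beyond the scatter) and the wider swap gives a 12-fold higher number from compound 2 to compound 4 (1.08 log units; beyond the scatter) although the methylamino chains stayed within the scatter of 1-hydroxyethyl. Against the chain without an amine there is also a 7.4-fold higher number from compound 1 to compound 4 (0.87 log units; beyond the scatter) so among these compounds methylamino is accommodated here and (2-hydroxyethyl)amino is not. Nothing shown gives a cause for this step.

The compounds shown leave open whether an ethyl or a 2-methoxyethyl group on that amine would behave like methyl or like 2-hydroxyethyl. As far as these compounds go, whether the opposite configuration at that saturated chain carbon matters with the longer substituent also stays open.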